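Methoxypyridinyl replacement for the fluoromethoxyphenyl alkyne of compound 2

The source may hold more compounds than are shown below. What is called first, only, known or untested is meant among the compounds shown, and "the series" means these compounds.

Measured so far in a functional assay on TREX cells for negative allosteric modulation of metabotropic glutamate receptor 3 (Rattus norvegicus), read by calcium flux, with a stated time of 2.5 min; a lower number here means a stronger inhibitor, a higher number a weaker inhibitor:
compound 1 `COc1ccc(C#Cc2ccc(C(=O)N3CCC[C@@H](CO)C3)cc2)c(F)c1F` gives > 10000 nM, a limit of the assay.
compound 2 `COc1ccc(C#Cc2ccc(C(=O)N3CCC[C@@H](CO)C3)cc2)cc1F` gives > 10000 nM, again only a limit.
compound 3 `COc1ccc(C#Cc2ccc(C(=O)N3CC[C@H](O)C3)cc2)cc1` gives 27500 nM.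

Compound 2 therefore stands at the limit, as the limit of > 10000 nM in this assay, at which 2 of the 3 values shown sit, states, so its true potency is not resolved; the step that the two limits leave unreadable from compound 1 to compound 2 from compound 1 is unreadable for the same reason. Within the data shown here, compound 3, with a different amine, is the only numerical value in the set and sits at weak potency.

Compound 4 `COc1ccc(C#Cc2ccc(C(=O)N3CCC[C@@H](CO)C3)cc2)cn1` differs from compound 2 by 6-methoxypyridin-3-yl in place of 3-fluoro-4-methoxyphenyl on a triple-bonded carbon. Among the measured compounds shown here, no measured step touches this change: the only step on record is unreadable, and compound 3 does not share the alkyne-aryl variation. The expectation rests on the set as a whole, in which every value is weak or at the limit. Compound 4 is therefore expected to remain weak, with a step that the limit leaves unreadable from compound 2 to compound 4 not beyond the scatter. The estimate for compound 4 in this assay is 15000 nM, within 5000 nM to 50000 nM, with a fair chance of another limit.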

Compound 4, half-maximal inhibitory concentration: > 10000 nM
Compound 4 ended at the assay's limit; the forecaster's own chance of this, stated with the estimate: 60%; the middle value is on the limit's open side.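

Compound 2 and compound 4 both stand at a limit rather than a number, so no step between them can be read: the limit of > 10000 nM in this assay, at which 3 of the 4 values shown sit.

The compounds shown leave open whether 6-methoxypyridin-3-yl in place of 3-fluoro-4-methoxyphenyl changes potency at all, and how compound 2 and compound 4 truly rank.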